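Aryl group change from compound 2 to compound 3

The compounds below may be only part of what the source reports. "The series", "measured", "known", "first", "only" and "open" are said of these compounds alone.

In a functional assay on HT-29 cells (Homo sapiens) for antiproliferative activity, read by sulforhodamine B assay, with a stated time of 48 h (on this read-out higher numbers stand for weaker inhibition and lower numbers for stronger inhibition), compound 1 `CCCN1CCN(c2ccc(S(=O)(=O)Oc3ccccc3OC)cc2)C1=O` gives > 100000 nM, which is a limit of the assay and not a number. Within the data shown here, compound 2 `CCCN1CCN(c2ccc(S(=O)(=O)Oc3cccc(OC)c3)cc2)C1=O` gives 25000 nM, the only true number so far. Among the measured compounds shown here, the one measured step, an at least 4.0-fold lower number from compound 1 to compound 2 (0.60 log units; beyond the scatter), comes with 3-methoxyphenyl in place of 2-methoxyphenyl on an oxygen. Its size is bounded on one side only, and it shows that a change in this aryl group can move the read-out beyond the scatter.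

Compound 3 `CCCN1CCN(c2ccc(S(=O)(=O)Oc3ccc(C)cc3)cc2)C1=O` is unmeasured and has 4-methylphenyl in place of 3-methoxyphenyl on an oxygen. For the measured compounds named here, no measured step covers this exact change, so the expectation stays close to compound 2 at 25000 nM, with no shift beyond the scatter. The expected step is a 1.2-fold higher number from compound 2 to compound 3 (0.08 log units; within the scatter). For compound 3 the estimate in this assay is 30000 nM, with an expected range from 8000 nM to 100000 nM.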

Compound 3, half-maximal inhibitory concentration: 25000 nM
Compound 3: the middle estimate sits 1.2-fold (0.08 log units) above what was measured; the range from low to high includes it.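

Replacing 3-methoxyphenyl with 4-methylphenyl on the oxygen gives no change at the digits printed from compound 2 to compound 3 (within the scatter) in this assay, so this aryl position accepts a second group, one without the hydrogen-bond acceptor counted in 3-methoxyphenyl, with no shift beyond the scatter. Measured against 2-methoxyphenyl, 4-methylphenyl gives an at least 4.0-fold lower number from compound 1 to compound 3 (0.60 log units; beyond the scatter), so two different aryl groups now lie on the same side of compound 1. The value of compound 1 is a limit of the assay, and both steps from it are bounded on one side only: the limit of > 100000 nM in this assay, at which 1 of the 3 values shown sits.

The group and its ring position change together in this step. 4-methoxyphenyl and 3-methylphenyl would be needed to separate the two changes. As far as these compounds go, it also remains open whether an aryl group carrying an amine, a carboxylic acid or a longer chain would move the number beyond the scatter from compound 3.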